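A replacement on the amide nitrogen of compound 3

The source may hold more compounds than are shown below. What is called first, only, known or untested is meant among the compounds shown, and "the series" means these compounds.

Compound 1, `CN(C)S(=O)(=O)c1ccccc1Nc1cc(-c2ccc3ccn(C)c3c2)c2nccnc2c1`, gives 7670 nM in an assay on lysate for inhibition of 6-phosphofructo-2-kinase/fructose-2,6-bisphosphatase 3 (Homo sapiens), with stated times of 0.5 min and 45 min; a lower number here means a stronger inhibitor, a higher number a weaker inhibitor. Compound 2, `Cn1ccc2ccc(-c3cc(Nc4ccccc4S(=O)(=O)NCC4CCOCC4)cc4nccnc34)cc21`, reaches only a limit in this assay, > 100000 nM. Compound 3, `Cn1ccc2ccc(-c3cc(Nc4cnccc4C(=O)NC4CCNC(=O)C4)cc4nccnc34)cc21`, gives 56500 nM in this assay.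

The three measured compounds share a core and differ in the aryl amine attached to it. Among the two numbers shown, compound 3 stands at the highest, with compound 1 giving a lower number; the remaining value is a limit, (the limit of > 100000 nM in this assay, at which 1 of the 3 values shown sits).

Compound 4, `CC(=O)N1CC(CNC(=O)c2ccncc2Nc2cc(-c3ccc4ccn(C)c4c3)c3nccnc3c2)C1`, is derived from compound 3 by a single change: (1-acetylazetidin-3-yl)methyl in place of 2-oxopiperidin-4-yl on an amide-type nitrogen. Within the data shown here, only one measured step exists, an at least 13-fold higher number from compound 1 to compound 2 (1.11 log units; beyond the scatter), and it concerns a different place, a sulfonyl sulfur rather than an amide-type nitrogen, with a substituent that grows rather than one that exchanges a ring for a chain bearing a smaller ring. It shows that enlarging this part of the molecule can push the number to the limit of this assay, but it does not transfer directly to the present change. With compound 3 already weak, the step from compound 3 to compound 4 is expected to be modest, a 1.2-fold higher number from compound 3 to compound 4 (0.09 log units; within the scatter), toward a higher number if anything. The estimate for compound 4 in this assay is therefore 70000 nM, with a range from 20000 nM to 200000 nM.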

Compound 4, half-maximal inhibitory concentration: > 100000 nM
Compound 4 gave a limit, no number; the forecaster's own chance of this, stated with the estimate: 40%; middle value at least 1.4-fold (0.15 log units) from the limit.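

In this assay, the exchange on the amide-type nitrogen gives an at least 1.7-fold higher number from compound 3 to compound 4 (0.24 log units; that floor lies within the scatter), so the change can be read only as a floor, and that floor does not establish a real loss. The result does show something that the earlier step on the sulfonyl sulfur could not: at this amide-type nitrogen, replacing 2-oxopiperidin-4-yl with (1-acetylazetidin-3-yl)methyl, which exchanges a six-membered ring for a four-membered ring on a methyl link and gives up the hydrogen-bond donor of the leaving group, brings no measurable gain in strength. Compound 4 ends at a limit and not at a number, which puts it with compound 2 at the top of the range of this assay: the limit of > 100000 nM in this assay, at which 2 of the 4 values shown sit.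

The donor, the ring size and the methyl link change together here, and the compounds shown do not separate them. From the compounds shown here alone, it also remains open whether a much smaller group on this nitrogen, such as a plain methyl, or a piperidin-4-yl carrying a free amine in place of the lactam carbonyl, would give a lower number than the 2-oxopiperidin-4-yl group does.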